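The compounds below may be only part of what the source reports. "The series", "measured", "known", "first", "only" and "open" are said of these compounds alone.

Series summary in a functional assay on HeLa cells (Homo sapiens) for inhibition, read by sulforhodamine B assay; on this read-out higher numbers stand for weaker inhibition and lower numbers for stronger inhibition:
compound 1 `O=C1C=C(Nc2ccccc2F)C(=O)c2c1nc1n2[C@H]2OC[C@@H](O)[C@H]2OC1`: 5120 nM
compound 2 `Cc1ccc(NC2=CC(=O)c3c(nc4n3[C@H]3OC[C@@H](O)[C@H]3OC4)C2=O)cc1`: 6590 nM
compound 3 `COc1ccccc1NC1=CC(=O)c2nc3n(c2C1=O)[C@H]1OC[C@@H](O)[C@H]1OC3`: 2950 nM

Compound 2 shows the highest number of the three; compound 1 lies nearest, within the scatter, while compound 3 lies further off, beyond the scatter. Compound 4 `CCOc1ccccc1NC1=CC(=O)c2c(nc3n2[C@H]2OC[C@@H](O)[C@H]2OC3)C1=O` is not yet measured in this assay. It differs from compound 2 as follows: 2-ethoxyphenyl in place of 4-methylphenyl on an amine nitrogen. Within the data shown here, one measured step bears on this change, a 1.7-fold lower number from compound 1 to compound 3 (0.24 log units; within the scatter), since compound 3, which carries a methoxy, gives the closest point of comparison to the ethoxy entering in compound 4. Compound 4 is therefore expected to land near compound 3, at 3500 nM (range 1500 nM to 8000 nM). The step this implies, a 1.9-fold lower number from compound 2 to compound 4 (0.27 log units; within the scatter), is expected to be toward a lower number, of a size that may not clear the scatter.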

Compound 4, half-maximal inhibitory concentration: 8300 nM
Estimate against measurement, compound 4: 2.4-fold (0.38 log units) below; the whole stated range lies below it.
By their numbers in this assay, from the lowest: compounds 3, 1, 2 and 4 (each within the scatter of the next, the first and the last beyond it).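

In this assay the change on the amine nitrogen gives a 1.3-fold higher number from compound 2 to compound 4 (0.10 log units; within the scatter) and so does not separate 2-ethoxyphenyl from 4-methylphenyl. Ethoxy does not match methoxy here: compound 3 gives 2950 nM and compound 4 gives 8300 nM with a gap beyond the scatter, so this position responds to a single added carbon between these two compounds. No measurement at hand accounts for that gap. Open, on these data alone, is whether a propoxy or longer alkoxy chain, or a hydroxy group, on the phenyl ring would track compound 3 or compound 4.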